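The source may hold more compounds than are shown below. What is called first, only, known or untested is meant among the compounds shown, and "the series" means these compounds.

Measured in an ADME assay on MCF7 cells (Homo sapiens) for cytotoxicity, with a stated time of 48 h; on this read-out lower numbers stand for stronger inhibition and higher numbers for weaker inhibition:
- compound 1 `C[C@H]1CCCCC(CCCC(Cl)Cl)c2c(O)cc(cc2O)[C@H](OC(N)=O)[C@@H](C)CCCCC(CCCC(Cl)Cl)c2c(O)cc(cc2O)[C@@H]1OC(N)=O`: 860 nM
- compound 2 `C[C@H]1CCCCC(CCCCCl)c2c(O)cc(cc2O)[C@H](OC(N)=O)[C@@H](C)CCCCC(CCCC(Cl)Cl)c2c(O)cc(cc2O)[C@@H]1OC(N)=O`: 1800 nM

Of these two compounds, compound 2 stands higher, at 1800 nM, and so is the weaker inhibitor in this assay. Compound 3 `CCCCC1CCCC[C@H](C)[C@@H](OC(N)=O)c2cc(O)c(c(O)c2)C(CCCC(Cl)Cl)CCCC[C@H](C)[C@@H](OC(N)=O)c2cc(O)c1c(O)c2` departs from it by a single change: hydrogen in place of chloro on a saturated chain carbon, four bonds along the chain from a saturated ring carbon. In words, hydrogen takes the place of chloro on a saturated chain carbon, four bonds along the chain from a saturated ring carbon.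

Within the data shown here, only one measured step bears on this. It is a 2.1-fold higher number from compound 1 to compound 2 (0.32 log units; beyond the scatter), a modest step that also put hydrogen in place of chloro on a saturated chain carbon. One step is a thin basis, but it points to another modest move toward a higher number. The expected change is a 1.8-fold higher number from compound 2 to compound 3 (0.25 log units; within the scatter). For compound 3 the estimated value is 3200 nM, with an expected range of 1400 nM to 7500 nM.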

Compound 3, half-maximal inhibitory concentration: 2200 nM
The estimate for compound 3 lay 1.5-fold (0.16 log units) above the measured number, within the range that was stated.
By their numbers in this assay, from the lowest: compound 1; then compounds 2 and 3 (each within the scatter of the next).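

In this assay, replacing the remaining chloro on this chain, four bonds along the chain from a saturated ring carbon, gave a 1.2-fold higher number from compound 2 to compound 3 (0.09 log units; within the scatter) and so did not separate compound 3 from compound 2. The change from chloromethyl to methyl therefore adds no readable shift here, unlike the earlier loss of chloro on the same chain. Over the whole replacement of dichloromethyl by methyl, the data show a 2.6-fold higher number from compound 1 to compound 3 (0.41 log units; beyond the scatter) and thus a difference that does stand clear of the scatter, though nothing shown gives a reason for this behaviour.

The compounds shown leave open whether the dichloromethyl group that compound 3 keeps would respond in the same way to losing its chloro atoms. They also leave open how a hydroxyl, an amine or a longer chain would read at this position.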